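The compounds below may be only part of what the source reports. "The series", "measured", "known", "first", "only" and "open" are said of these compounds alone.

Compound 1 `Cc1ccccc1NC(=O)Nc1cc(C(C)(C)C)nn1-c1ccccc1` is one of two ureas built on a shared core, and in an assay on isolated protein for inhibition of serine/threonine-protein kinase 10 (Homo sapiens), read by thermal shift assay, tested at 10 uM (a higher number here means that the compound stabilises the target more against heat, a lower number that the compound stabilises the target less), compound 1 gives 8.6 degrees C. Compound 2 `CCOc1ccc(NC(=O)Nc2cc(C(C)(C)C)nn2-c2ccccc2)cc1` differs only in the aryl group on the amide-type nitrogen; in this assay compound 2 gives 0.8 degrees C, and the change a number 7.8 degrees C lower from compound 1 to compound 2 (beyond the scatter) shows how much was lost. Among the measured compounds shown here, compound 2 therefore stands lowest of the two numbers measured so far, with compound 1 the nearer and higher one.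

Compound 3 `CC(C)(C)c1cc(NC(=O)Nc2ccc(F)cc2)n(-c2ccccc2)n1` is not yet measured. It carries fluoro in place of ethoxy on an aromatic carbon. For the measured compounds named here, only one measured step bears on this place, the large drop from compound 1 to compound 2, and it says that this aryl group matters strongly, but nothing measured tells what a fluoro group does there. A partial return toward compound 1 seems a cautious expectation. The step is estimated as a number 2.7 degrees C higher from compound 2 to compound 3 (beyond the scatter). Compound 3 is expected to give about 3.5 degrees C, within a range from 0 degrees C to 7.5 degrees C.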

Compound 3, shift of the target's melting temperature: 6.5 degrees C
The estimate for compound 3 lay 3.0 degrees C below the measured number, and the stated range covers the measured number.
By their numbers in this assay, from the lowest: compound 2; then compound 3; then compound 1.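

Exchanging ethoxy for fluoro on this aromatic carbon, with the rest of the molecule unchanged, gives a number 5.7 degrees C higher from compound 2 to compound 3 (beyond the scatter) in this assay, so a group at this place does not in itself cost most of the stabilisation: the outcome depends on which group sits there. The comparison with the 2-methylphenyl group gives a number 2.1 degrees C lower from compound 1 to compound 3 (beyond the scatter), so the 4-fluorophenyl group recovers much of what the 4-ethoxyphenyl group lost, though not all of it. Nothing available explains the difference between ethoxy and fluoro.

The compounds shown leave open how a methoxy, chloro or amino group would read on this same carbon, and so whether ethoxy is an exception. On these data alone, it also remains open what a single phenyl ring carrying both the 2-methyl and the 4-fluoro groups would give.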